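Cytotoxicity series: benzamide to furanamide to fluorobenzamide

The source may report more compounds than this note shows. Statements on the series, on what has been measured and on what is new or still open speak of the compounds shown alone.

Measured compounds:
- compound 1 `CN(C)c1cc2[nH]c(C3CCCCC3)nc2cc1NC(=O)c1ccccc1`, > 100 ug/mL
- compound 2 `CN(C)c1cc2[nH]c(C3CCCCC3)nc2cc1NC(=O)c1ccco1`, > 100 ug/mL

In an ADME assay on Vero cells (Chlorocebus sabaeus) for cytotoxicity, read by resazurin assay, with a stated time of 3 days (a lower number here means a stronger inhibitor, a higher number a weaker inhibitor), compound 1 gives only a limit, > 100 ug/mL. In this assay compound 2 likewise gives only a limit, > 100 ug/mL. The step that the two limits leave unreadable from compound 1 to compound 2 is therefore not readable, and compound 2 stands at the limit shared by both values (the limit of > 100 ug/mL in this assay, at which 2 of the 2 values shown sit). Compound 3 `CN(C)c1cc2[nH]c(C3CCCCC3)nc2cc1NC(=O)c1ccc(F)cc1` carries the change (4-fluorophenyl in place of furan-2-yl on a carbonyl carbon). For the measured compounds named here, no measured step gives its size; the step that the limit leaves unreadable from compound 2 to compound 3 is expected to stay within the scatter, with compound 3 expected to sit at the limit again. The estimate for compound 3 is 150 ug/mL, in the range 70 ug/mL to 400 ug/mL.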

Compound 3, half-maximal inhibitory concentration: > 100 ug/mL
Compound 3 was reported as a limit; the forecaster's own chance of this, stated with the estimate: 85%; the middle value is on the limit's open side.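

In this assay no step among compound 1, compound 2 and compound 3 can be read, all three values being limits and not numbers: the limit of > 100 ug/mL in this assay, at which 3 of the 3 values shown sit.

The compounds shown leave open where each truly lies beyond that limit, and whether any change on the carbonyl carbon alters cytotoxicity.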